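Swapping pyridin-3-yl for 3-chlorophenyl in a cytotoxicity test

The source may hold more compounds than are shown below. What is called first, only, known or untested is meant among the compounds shown, and "the series" means these compounds.

Values so far in an ADME assay on Raji cells (Homo sapiens) for cytotoxicity, with a stated time of 72 h (on this read-out lower numbers stand for an effect already at smaller amounts and higher numbers for an effect only at larger amounts of compound), are as follows.
Compound 1 (`Cc1cc(NC(=O)Nc2ccc(Cl)c(Cl)c2)c2ccccc2n1`) gives 10000 nM as a measured number
Compound 2 (`Cc1cc(NC(=O)Nc2cccc(C(N)=O)c2)c2ccccc2n1`) gives > 25000 nM as a limit
Compound 3 (`Cc1cc(NC(=O)Nc2cccnc2)c2ccccc2n1`) gives > 25000 nM as a limit

Compound 3 stands at the limit of > 25000 nM in this assay, at which 2 of the 3 values shown sit, and so has only a limit, not an exact number. That gives the comparison a loose starting point.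

Compound 4 (`Cc1cc(NC(=O)Nc2cccc(Cl)c2)c2ccccc2n1`) has not been measured yet. It differs from compound 3 in one place (3-chlorophenyl in place of pyridin-3-yl on an amide-type nitrogen), with 3-chlorophenyl in place of pyridin-3-yl on an amide-type nitrogen.

Within the data shown here, no two measured compounds differ in only one place, so no measured step shows what this swap does. Among the measured compounds shown here, the only guide is compound 1, which gives 10000 nM as the sole real number of the set and is also the only measured compound that carries chlorine. One compound is thin support, so only a modest move towards lower numbers is expected in this assay and the assay may again report just a limit. The estimated change is a step of an at least 1.3-fold lower number from compound 3 to compound 4 (0.14 log units; that floor lies within the scatter) and it remains rough. The expected value for compound 4 is 18000 nM within a range of 8000 nM to 35000 nM as estimated here.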

Compound 4, half-maximal effective concentration: 18000 nM
Compound 4: the middle estimate sits on the measured number at the digits printed; the measured number falls inside the stated range.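

In this assay, compound 4 shows that a ring with a single chlorine can already give a real number rather than a limit. As far as these compounds go, the swap at the amide-type nitrogen gives an at least 1.3-fold lower number from compound 3 to compound 4 (0.14 log units; that floor lies within the scatter), and chloro in place of carbamoyl on an aromatic carbon gives an at least 1.3-fold lower number from compound 2 to compound 4 (0.14 log units; that floor lies within the scatter); compound 2 and compound 3 each have only a limit, so the true size of both steps stays unknown: the limit of > 25000 nM in this assay, at which 2 of the 4 values shown sit. Among these compounds, the one step with two real numbers, hydrogen in place of chloro on an aromatic carbon, gives a 1.8-fold higher number from compound 1 to compound 4 (0.26 log units; within the scatter), so the extra chloro of compound 1 has no effect that can be told apart from the scatter.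

From the compounds shown here alone, it remains open whether a carboxylic acid or an amine in place of the chloro of compound 4 would give a real number or only a limit. Going by these compounds, what a longer chain in place of the methyl on the shared core would do in this assay also remains open.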